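The source may hold more compounds than are shown below. What is called first, only, known or untested is meant among the compounds shown, and "the series" means these compounds.

Three amides sharing one core have been compared in a functional assay on the whole organism (strain Wistar) for inhibition, with Rattus norvegicus as the target, read by paw edema, with stated times of 60 min and 2 h, at a dose of 100 mg/kg by the oral route; on this read-out lower numbers stand for less inhibition and higher numbers for more inhibition at the one dose given (going by the name of the read-out). Compound 1 `CCN(CC)C(=O)CC1CCc2cc(OC)c(OC)cc21` gives 40% in this assay. Compound 2 `COc1cc2c(cc1OC)C(CC(=O)NC(C)C)CC2` gives 37%, and compound 3 `CCCCNC(=O)CC1CCc2cc(OC)c(OC)cc21` gives 24%. Compound 3 stands lowest of the three numbers: its nearest neighbour is compound 2, and the step of a number 13 percentage points lower from compound 2 to compound 3 (beyond the scatter) lies beyond the scatter, as does the larger step of a number 16 percentage points lower from compound 1 to compound 3 (beyond the scatter). The step of a number 3 percentage points lower from compound 1 to compound 2 (within the scatter), by contrast, lies within the scatter.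

Compound 4 `CCCCCNC(=O)CC1CCc2cc(OC)c(OC)cc21` is the next member and has not yet been measured in this assay. It differs from compound 3 by methyl in place of hydrogen on a saturated chain carbon, four bonds along the chain from an amide-type nitrogen. Among the compounds with values here, the one measured step that bears on this change is the move from isopropyl to butyl on the amide-type nitrogen, a number 13 percentage points lower from compound 2 to compound 3 (beyond the scatter), where the longer chain went with lower inhibition. One step is a thin basis, and a further single carbon is a small change, so only a small drop or none beyond the scatter is expected. Compound 4 is therefore estimated at 19%, between 7% and 31%, a step of a number 5 percentage points lower from compound 3 to compound 4 (within the scatter) expected from compound 3.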

Compound 4, a percentage reported as inhibition, in the whole organism at one dose (the size of the read-out at that dose, not a potency): 34%
Estimate against measurement, compound 4: 15 percentage points below, outside the stated range (above it).
By their numbers in this assay, from the lowest: compounds 3, 4, 2 and 1 (each within the scatter of the next, the first and the last beyond it).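

In this assay, the methyl at this place, four bonds along the chain from the amide-type nitrogen, gives a number 10 percentage points higher from compound 3 to compound 4 (within the scatter), so the fall that went with butyl in place of isopropyl is not carried on by the longer chain. Compound 4 also stays within the scatter of the other two amides, with a number 3 percentage points lower from compound 2 to compound 4 (within the scatter) and a number 6 percentage points lower from compound 1 to compound 4 (within the scatter), whereas compound 3 lay beyond the scatter of both. At this one dose, pentyl on the amide-type nitrogen therefore cannot be told apart from isopropyl or from diethylamino on the carbonyl carbon. Nothing at hand gives a reason for these numbers. From the compounds shown here alone, whether a hexyl chain, a branched pentyl chain or a phenyl ring on the amide nitrogen would stand apart from these four amides remains open.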